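Oxime acetates and hydrazones on a shared core

The compounds below may be only part of what the source reports. "The series", "measured", "known", "first", "only" and "open" are said of these compounds alone.

Compound 1 `COc1cc(/C(=N\OC(C)=O)c2ccc3c(ccn3C)c2)cc(OC)c1OC` — > 10000 nM
Compound 2 `CCn1ccc2cc(/C(=N/OC(C)=O)c3cc(OC)c(OC)c(OC)c3)ccc21` — > 1000 nM
Compound 3 `COc1cc(/C(=N/N)c2ccc3c(ccn3C)c2)cc(OC)c1OC` — > 10000 nM

Of the compounds shown here, three have been measured in a functional assay on HL-60 cells (Homo sapiens) for cytotoxicity, read by XTT assay, with a stated time of 72 h; a lower number here means a stronger inhibitor, a higher number a weaker inhibitor. In this assay compound 1 gives only a limit, > 10000 nM, and no number. Compound 2 likewise reaches only a limit, > 1000 nM. Compound 3, too, gives a limit, > 10000 nM, and no number.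

Compound 2 differs from compound 1 by methyl in place of hydrogen on a saturated chain carbon bound to an aromatic nitrogen. Because both values are limits, the step that the two limits leave unreadable from compound 1 to compound 2 cannot be read; one value sits at the limit of > 1000 nM in this assay, at which 1 of the 3 values shown sits, and the other at the limit of > 10000 nM in this assay, at which 2 of the 3 values shown sit. Compound 3 carries a different end group in place of the oxime acetate, and the difference between the two cores is not broken down here.

The unmeasured compound 4 `CCn1ccc2cc(/C(=N\N)c3cc(OC)c(OC)c(OC)c3)ccc21` differs from compound 3 by methyl in place of hydrogen on a saturated chain carbon bound to an aromatic nitrogen, the same change as that from compound 1 to compound 2, at the same place. Since that earlier change gave nothing readable, and since compound 3 itself sits at a limit, > 10000 nM, compound 4 is expected to stay at or near that limit, with an estimated step that the limit leaves unreadable from compound 3 to compound 4. The estimate for compound 4 in this assay is 20000 nM, with a range from 4000 nM to 100000 nM, and most likely the assay will again report only a limit.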

Compound 4, half-maximal inhibitory concentration: > 1000 nM
Compound 4: only a limit was reported; the forecaster's own chance of this, stated with the estimate: 80%; the middle value does not contradict the limit.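

In this assay compound 4 gives only a limit, > 1000 nM, and no number. Compound 3 likewise gives only a limit, > 10000 nM, and the step between compound 3 and compound 4 cannot be read. With all four compounds at limits, the compounds shown leave open what any of them actually measures in this assay, and whether methyl in place of hydrogen changes it at all.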